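The source may report more compounds than this note shows. Statements on the series, on what has been measured and on what is new or still open speak of the compounds shown alone.

Two azetidine cyanamides have been measured against the enzyme. Compound 1 `N#CN1CC(OCc2ccc(-c3cccc(OCc4ccccc4)c3)cc2)C1` gives 1.4 nM in an assay on isolated protein for inhibition of N-acylethanolamine-hydrolyzing acid amidase (Homo sapiens), read by fluorescence, with a stated time of 90 min (a lower number here means a stronger inhibitor, a higher number a weaker inhibitor), and compound 2 `N#CN1CC(OCc2ccc(Oc3ccccc3)cc2Br)C1` gives 1.03 nM in the same assay, so the two numbers lie within the scatter of each other and neither can be called stronger. Compound 3 `N#Cc1ccccc1-c1cc(Oc2ccccc2)ccc1COC1CN(C#N)C1` differs from compound 2 in one place: 2-cyanophenyl in place of bromo on an aromatic carbon. For the measured compounds named here, no measured pair shows this kind of change, so its effect is unknown; a small to moderate loss seems the likelier outcome. Compound 3 is expected to give 4 nM, in a range from 1 nM to 20 nM, a step of a 3.9-fold higher number from compound 2 to compound 3 (0.59 log units; beyond the scatter) that is estimated, not measured.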

Compound 3, half-maximal inhibitory concentration: 6.6 nM
Beside the measured number, compound 3's estimate is 1.7-fold (0.22 log units) below it, within the range that was stated.
By their numbers in this assay, from the lowest: compounds 2 and 1 (each within the scatter of the next); then compound 3.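

For the compounds shown here, replacing bromo with 2-cyanophenyl on this aromatic carbon gives a 6.4-fold higher number from compound 2 to compound 3 (0.81 log units; beyond the scatter), the only step between measured compounds so far and one that lies beyond the scatter. This position can therefore carry a much larger group, with an added aromatic ring, at a modest loss of inhibition. Nothing available explains that loss. The compounds shown leave open whether the ring or its nitrile accounts for the step. They also leave open how a methyl group, an amine or a carboxylic acid would fare at this position.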